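The source may hold more compounds than are shown below. What is called first, only, known or untested is meant among the compounds shown, and "the series" means these compounds.

Measured so far in a functional assay on HeLa cells for antagonist activity at 5-hydroxytryptamine receptor 6 (Homo sapiens), read by cAMP accumulation and immunoassay; on this read-out lower numbers stand for stronger inhibition and higher numbers for weaker inhibition:
- compound 1 `O=S(=O)(c1ccccc1F)c1cn(C2CCNC2)c2ncccc12`: 50 nM
- compound 2 `CN1CCC(n2cc(S(=O)(=O)c3ccccc3F)c3cccnc32)C1`: 186 nM
- compound 3 `CN1CCC(n2cc(S(=O)(=O)c3ccc(F)cc3)c3cccnc32)C1`: 213 nM

Compound 2 sits beyond the scatter from compound 1 (a 3.7-fold higher number from compound 1 to compound 2 (0.57 log units; beyond the scatter)) and within the scatter of compound 3 (a 1.1-fold higher number from compound 2 to compound 3 (0.06 log units; within the scatter)). Compound 4 `CN1CCC(n2cc(S(=O)(=O)c3ccccc3Cl)c3cccnc32)C1` differs from compound 2 by chloro in place of fluoro on an aromatic carbon. For the measured compounds named here, no measured step swaps one halogen for another on this ring. The nearest comparison is the move of the fluoro on the same ring, a 1.1-fold higher number from compound 2 to compound 3 (0.06 log units; within the scatter), which stayed within the scatter; the step 1>2 concerns the amine nitrogen and does not bear on the sulfonyl ring. On that basis the step from compound 2 to compound 4 is expected to stay within the scatter, a 1.1-fold higher number from compound 2 to compound 4 (0.03 log units; within the scatter). Compound 4 is therefore estimated at 200 nM, range 90 nM to 450 nM.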

Compound 4, half-maximal inhibitory concentration: 91 nM
Compound 4: middle estimate off by 2.2-fold (0.34 log units), on the high side; measured number inside the range.
By their numbers in this assay, from the lowest: compounds 1 and 4 (each within the scatter of the next); then compounds 2 and 3 (each within the scatter of the next).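

On the sulfonyl ring, the identity of the halogen matters where moving the fluoro did not: chloro in place of fluoro, on an aromatic carbon ortho to a large group, gives a 2.0-fold lower number from compound 2 to compound 4 (0.31 log units; beyond the scatter) as a modest step. The swap of 4-fluorophenyl for 2-chlorophenyl gives a 2.3-fold lower number from compound 3 to compound 4 (0.37 log units; beyond the scatter) on the same ring. No measurement here explains the difference between the two halogens.

Bromo or methyl at this position remains open, as does 4-chlorophenyl. So does whether chloro gives a similar step on compound 1, with its unsubstituted amine nitrogen.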